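Methyl for Cyano on the Thiophene Carbon of Compound 3

This account rests on a few compounds, and the source may have more. Where it says the series, first, only, none or still open, it means among the compounds named here.

Measured compounds:
- compound 1, `CC#C[C@@H](Cc1nnn[nH]1)c1ccc(OCc2ccc3scc(-c4cc(OCCOC)ccc4C)c3c2)cc1`: 26 nM
- compound 2, `CC#C[C@@H](Cc1nnn[nH]1)c1ccc(OCc2ccc3scc(C4CCCCC4)c3c2)cc1`: 16 nM
- compound 3, `CC#C[C@@H](Cc1nnn[nH]1)c1ccc(OCc2ccc3sc(C#N)c(-c4ccccc4C)c3c2)cc1`: 19 nM

The three compounds share one core and were tested in a functional assay on cells for agonist activity at Free fatty acid receptor 1 (Rattus norvegicus), read by FLIPR and calcium flux; a lower number here means that less compound is needed, a higher number that more compound is needed for the effect. Compound 3 gives 19 nM, the middle of the three values; compound 2 gives 16 nM and compound 1 gives 26 nM, and each of these lies within the scatter of compound 3.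

Compound 4, `CC#C[C@@H](Cc1nnn[nH]1)c1ccc(OCc2ccc3sc(C)c(-c4ccccc4C)c3c2)cc1`, is not yet measured. It differs from compound 3 by methyl in place of cyano on an aromatic carbon.

Going by the values given here, only one measured step exists, a 1.6-fold lower number from compound 1 to compound 2 (0.21 log units; within the scatter). That step exchanges the group on the other ring carbon of the fused system and says nothing direct about the cyano position next to the ring sulfur. Among the compounds with values here, nothing among the measured compounds bears on a cyano-to-methyl exchange, so no step beyond the scatter is expected in this assay in either direction.

Compound 4 is therefore expected to give about 19 nM, within a range from 8 nM to 45 nM. The step from compound 3 is estimated as no change at the digits printed from compound 3 to compound 4 (within the scatter), a change not beyond the scatter.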

Compound 4, half-maximal effective concentration: 10 nM
Compound 4: the middle estimate sits 1.9-fold (0.28 log units) above what was measured, and the stated range covers the measured number.
By their numbers in this assay, from the lowest: compounds 4, 2, 3 and 1 (each within the scatter of the next, the first and the last beyond it).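

In this assay, going by these compounds alone, the first measured exchange on this aromatic carbon next to the ring sulfur, methyl in place of cyano, gives a 1.9-fold lower number from compound 3 to compound 4 (0.28 log units; within the scatter). The position therefore accepts a swap from cyano, with its triple bond and hydrogen-bond acceptor, to methyl, which has neither, without a step beyond the scatter, at least while the neighbouring ring atom bears a 2-methylphenyl group. No measurement of any property of these two groups accompanies this result, and the compounds offer no explanation of the step.

The compounds shown leave open how this position responds to groups of other kinds, such as an amine, a carboxylic acid or a longer chain like n-butyl, since cyano and methyl are the only two groups compared here with the rest of the structure held constant. They also leave open whether the same exchange would give a similar step when the 2-methylphenyl group is replaced by the cyclohexyl group of compound 2 or by the larger aryl group of compound 1.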